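The source may hold more compounds than are shown below. What is called first, only, known or untested is meant among the compounds shown, and "the series" means these compounds.

Going by the values given here, in a functional assay on HeLa cells (Homo sapiens) for antiproliferative activity, read by sulforhodamine B assay, with a stated time of 72 h (a lower number here means a stronger inhibitor, a higher number a weaker inhibitor), compound 2 `Fc1cccc(NC(=S)N/N=C/c2ccc3ccccc3n2)c1` gives 70100 nM, the only true number so far in this small series. Compound 1 `S=C(N/N=C/c1ccc2ccccc2n1)Nc1ccccc1Br` gives > 100000 nM, which is a limit and not a number. Among the compounds with values here, the one measured step, an at least 1.4-fold lower number from compound 1 to compound 2 (0.15 log units; that floor lies within the scatter), puts 3-fluorophenyl in place of 2-bromophenyl, and its floor stays within the usual scatter. As far as these compounds go, the full size of that step with compound 1 stays open because of the limit of > 100000 nM in this assay, at which 1 of the 2 values shown sits. Compound 3 `S=C(N/N=C/c1ccc2ccccc2n1)Nc1ccccc1` keeps the core of compound 2 but has hydrogen in place of fluoro on an aromatic carbon, meta to a large group, so that 3-fluorophenyl becomes phenyl: hydrogen in place of fluoro on an aromatic carbon. Within the data shown here, only the step of an at least 1.4-fold lower number from compound 1 to compound 2 (0.15 log units; that floor lies within the scatter) touches this part of the structure, and it shows no change beyond the scatter, so no step beyond the scatter is expected in this assay, in either direction. The expected change is a 1.0-fold lower number from compound 2 to compound 3 (0.00 log units; within the scatter). For compound 3 the estimated value is 70000 nM, with an expected range from 30000 nM to 100000 nM.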

Compound 3, half-maximal inhibitory concentration: 27400 nM
Beside the measured number, compound 3's estimate is 2.6-fold (0.41 log units) above it, and the stated range ends above it.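

In this assay, going by these compounds alone, the change from 3-fluorophenyl to phenyl gives a 2.6-fold lower number from compound 2 to compound 3 (0.41 log units; beyond the scatter), the first step at this aromatic carbon that clears the scatter, so this fluoro is not an interchangeable replacement for hydrogen here. Hydrogen in place of bromo gives an at least 3.6-fold lower number from compound 1 to compound 3 (0.56 log units; beyond the scatter), so among the three compounds shown, both halogen-bearing compounds carry higher numbers than the phenyl compound, although the bromo and the fluoro do not stand at the same place on the ring. The value of compound 1 is a limit and not a number, so the step involving it has a floor but no known full size: the limit of > 100000 nM in this assay, at which 1 of the 3 values shown sits.

The compounds shown leave open whether the lower number with phenyl reflects the absence of halogen in general or only of these two halogens at these two places, since a fluoro at another place on the ring or a chloro at the same place would separate those readings. They also leave open how a different kind of group on this aromatic carbon, such as an amine, a methoxy group or a carboxylic acid, would shift the number in this assay.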